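Thiophen-3-yl in place of 3-fluorophenyl: expected step for compound 4

The source may hold more compounds than are shown below. What is called first, only, known or untested is meant among the compounds shown, and "the series" means these compounds.

Measured so far in a functional assay on MCF7 cells (Homo sapiens) for inhibition, with a stated time of 72 h; on this read-out lower numbers stand for stronger inhibition and higher numbers for weaker inhibition:
- compound 1 `NC1CCC(Nc2nc(NCc3ccc(-c4ccsc4)cc3)c3ncn(C4CCCC4)c3n2)CC1` gives 145 nM
- compound 2 `NC1CCC(Nc2nc(NCc3ccc(-n4cccn4)cc3)c3ncn(C4CCCC4)c3n2)CC1` gives 139 nM
- compound 3 `NC1CCC(Nc2nc(NCc3ccc(-c4cccc(F)c4)nc3)c3ncn(C4CCCC4)c3n2)CC1` gives 33 nM

Compound 3 at 33 nM stands lowest of the three numbers, and its gaps to compound 1 and to compound 2 both lie beyond the scatter. The unmeasured compound 4 `NC1CCC(Nc2nc(NCc3ccc(-c4ccsc4)nc3)c3ncn(C4CCCC4)c3n2)CC1` differs from compound 3 in one place: thiophen-3-yl in place of 3-fluorophenyl on an aromatic carbon with thiophen-3-yl in place of 3-fluorophenyl on an aromatic carbon, next to the ring nitrogen.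

Among the measured compounds shown here, only one measured step is available, a 1.0-fold lower number from compound 1 to compound 2 (0.02 log units; within the scatter), and it lies within the scatter. It does not involve 3-fluorophenyl, so it bears only loosely on this change. Compound 1 carries the same thiophen-3-yl and gives 145 nM, but its ring differs from the six-membered aromatic ring with 1 nitrogen in compound 4. For the measured compounds named here, no measured step isolates that difference.

A modest move toward a higher number is therefore expected in this assay, with compound 4 staying nearer to compound 3 than to compound 1. The estimated step is a 2.1-fold higher number from compound 3 to compound 4 (0.33 log units; beyond the scatter) as the working expectation. For compound 4 the estimated value is 70 nM with an expected range from 25 nM to 190 nM.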

Compound 4, half-maximal inhibitory concentration: 100 nM
Estimate against measurement, compound 4: 1.4-fold (0.15 log units) below, within the range that was stated.
By their numbers in this assay, from the lowest: compound 3; then compounds 4, 2 and 1 (each within the scatter of the next).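

On the aromatic carbon next to the ring nitrogen, para to a large group, the identity of the aromatic substituent now registers in this assay: thiophen-3-yl in place of 3-fluorophenyl gives a 3.0-fold higher number from compound 3 to compound 4 (0.48 log units; beyond the scatter), a modest step beyond the scatter, with 3-fluorophenyl the better of the two groups here. Among the compounds shown here, changing the whole arm does not separate compound 4 from the earlier compounds: 6-(thiophen-3-yl)pyridin-3-yl in place of 4-(thiophen-3-yl)phenyl gives a 1.5-fold lower number from compound 1 to compound 4 (0.16 log units; within the scatter), and the same group in place of 4-(1H-pyrazol-1-yl)phenyl gives a 1.4-fold lower number from compound 2 to compound 4 (0.14 log units; within the scatter), both within the scatter, so the ring nitrogen with thiophen-3-yl does not by itself reproduce the low number of compound 3. No measurement at hand offers an explanation for the step from 3-fluorophenyl to thiophen-3-yl.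

Still open, going by these compounds, is whether the step belongs to the fluorine or to the six-membered aromatic ring of carbon only in 3-fluorophenyl, a question that an unsubstituted phenyl at this place would settle. Also open, on these data alone, is how 3-fluorophenyl behaves on the carbon-only ring carried by compound 1 and compound 2.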